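A few compounds are considered here, and "the series" means these few. Any claim that something is new, unique, unknown or untested is made for them only; others in the source may bear on it.

Compound 2 `CC(C)(C)OC(=O)N1CCN(CC(=O)Nc2ccc(C(=O)/C=C/c3cn(Cc4ccc(Br)cc4)nn3)cc2)CC1` gives the lowest of three numbers in a functional assay on MCF7 cells (Homo sapiens) for inhibition, read by MTT assay (on this read-out higher numbers stand for weaker inhibition and lower numbers for stronger inhibition), at 31000 nM, yet compound 3 `CCCCCCCCn1cc(/C=C/C(=O)c2ccc(NC(=O)CN3CCN(c4ccccc4)CC3)cc2)nn1` with 31900 nM and compound 1 `CCCCCCCCCCn1cc(/C=C/C(=O)c2ccc(NC(=O)CN3CCN(C(=O)OC(C)(C)C)CC3)cc2)nn1` with 40000 nM both stand within the usual scatter of it, so no ordering can be claimed. Within the data shown here, the only single-site step measured, a 1.3-fold lower number from compound 1 to compound 2 (0.11 log units; within the scatter), lies within that scatter. Compound 4 `COc1ccccc1N1CCN(CC(=O)Nc2ccc(C(=O)/C=C/c3cn(Cc4ccc(Br)cc4)nn3)cc2)CC1` differs from compound 2 by 2-methoxyphenyl in place of tert-butoxycarbonyl on an amine nitrogen in a ring. Among the measured compounds shown here, no measured step isolates this change; compound 3 carries a plain phenyl on that nitrogen and compound 1 carries the tert-butoxycarbonyl, and their values sit close together, though they also differ at the chain. A step of a 1.0-fold lower number from compound 2 to compound 4 (0.01 log units; within the scatter) is therefore expected, no larger than the scatter, so compound 4 is estimated at 30000 nM, between 12000 nM and 75000 nM.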

Compound 4, half-maximal inhibitory concentration: 36800 nM
The estimate for compound 4 lay 1.2-fold (0.09 log units) below the measured number; the range from low to high includes it.
By their numbers in this assay, from the lowest: compounds 2, 3, 4 and 1 (each within the scatter of the next).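

In this assay, the first step measured at this amine nitrogen in a ring gives a 1.2-fold higher number from compound 2 to compound 4 (0.07 log units; within the scatter) when 2-methoxyphenyl takes the place of tert-butoxycarbonyl. The group that leaves has no ring and the group that enters carries a six-membered aromatic ring, yet this exchange produces no readable difference in the number. No supporting measurement bears on this result. Still open, going by these compounds, is whether a chain ending in an amine or a carboxylic acid on this nitrogen would give a step beyond the scatter.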